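The source may report more compounds than this note shows. Statements on the series, on what has been measured and on what is new or still open speak of the compounds shown alone.

Working notes on a small set of diaryl heterocycles carrying a long saturated chain.

Compound 1 is `CCCCCCCn1nc(-c2ccccc2)c(-c2ccccc2)cc1=O` and compound 2 is `CCCCCCCCCn1nc(-c2ccccc2)c(-c2ccccc2)cc1=O`; the two share a core and differ only in the chain. In an assay on microsomes from liver for inhibition of sterol O-acyltransferase 1 (Rattus norvegicus) (a lower number here means a stronger inhibitor, a higher number a weaker inhibitor), compound 1 gives 86000 nM, and compound 2 gives 85000 nM. The change between them is ethyl in place of hydrogen on a saturated chain carbon, seven bonds along the chain from an aromatic nitrogen, and the step it made is a 1.0-fold lower number from compound 1 to compound 2 (0.01 log units; within the scatter). The two values lie within the scatter of each other, so no order is read from them.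

Compound 3 is `CCCCCCCSc1cc(-c2ccccc2)c(-c2ccccc2)nn1`, built on a different core; the difference between the two cores is not broken down here. In this assay compound 3 gives 76000 nM, a value within the scatter of both compound 1 and compound 2.

Compound 4 is `CCCCCCCCCSc1cc(-c2ccccc2)c(-c2ccccc2)nn1`, not yet measured. It differs from compound 3 by ethyl in place of hydrogen on a saturated chain carbon, seven bonds along the chain from a sulfur. This is the same kind of change as that from compound 1 to compound 2, not the same: in both the ethyl enters on a saturated chain carbon seven bonds along the chain, but here the chain is counted from a sulfur, where before it was counted from an aromatic nitrogen.

Beside the earlier step of a 1.0-fold lower number from compound 1 to compound 2 (0.01 log units; within the scatter), the step expected from this change is a 1.0-fold lower number from compound 3 to compound 4 (0.01 log units; within the scatter). The expectation rests on that one measured pair, where the same kind of lengthening left the number within the scatter.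

Compound 4 is therefore expected at 75000 nM, within a range from 35000 nM to 160000 nM.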

Compound 4, half-maximal inhibitory concentration: 116000 nM
Beside the measured number, compound 4's estimate is 1.5-fold (0.19 log units) below it; the range from low to high includes it.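

Among these compounds, the lengthening on the core of compound 3 gives a 1.5-fold higher number from compound 3 to compound 4 (0.18 log units; within the scatter) in this assay, so the change leaves no step that can be told from the scatter on this core. Set beside the step on the core of compound 1, the new step does not differ from the earlier one, and the change carries from one core to the other without a gap that can be read: the same change on two cores in this assay, a 1.0-fold lower number (0.01 log units; within the scatter) from compound 1 to compound 2 and a 1.5-fold higher number (0.18 log units; within the scatter) from compound 3 to compound 4, 1.5-fold (0.19 log units) apart, within the scatter of two such steps. This shows only that ethyl in place of hydrogen at this place on the chain gave a step within the scatter on both cores; it does not show that the change has no effect at all, that the two cores respond in the same way, or that the result would hold on a third core, and a small real step on either core would not be visible in these two pairs.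

Going by these compounds, whether a longer chain, or a much shorter one such as methyl, would give a step beyond the scatter on either core remains open. Also open, on these data alone, is whether an amine or a carboxylic acid carried on the chain would move the number in this assay on these cores.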